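The source may report more compounds than this note shows. Statements on the series, on what has been measured and on what is new or still open speak of the compounds shown alone.

Compound 1 `O=C(Nc1ccc(Cl)cc1)c1cc(=O)[nH]c2cc(Br)ccc12` — > 20000 nM
Compound 2 `O=C(Nc1cccc(OC(F)(F)F)c1)c1cc(=O)[nH]c2cc(Br)ccc12` — 14000 nM
Compound 3 `CC(=O)c1ccc(-c2ccc3c(C(=O)Nc4cccc(F)c4)cc(=O)[nH]c3c2)cc1` — > 20000 nM

Of the compounds shown here, three of this shared core have been tested in a functional assay on KYSE-410 cells (Homo sapiens) for antiproliferative activity, read by MTT assay, with a stated time of 72 h; a higher number here means a weaker inhibitor, a lower number a stronger inhibitor. For compound 1 the result is a limit of the assay, > 20000 nM, and not a number. Among the compounds with values here, compound 2 gives 14000 nM, the only actual number among the three. For compound 3 the result is again only a limit, > 20000 nM. Compound 3 therefore sits at the limit of > 20000 nM in this assay, at which 2 of the 3 values shown sit, so its true potency is not known beyond being weak.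

Compound 4 `Cc1cc(-c2ccc3c(C(=O)Nc4cccc(F)c4)cc(=O)[nH]c3c2)c(C)cc1F` differs from compound 3 in one place: 4-fluoro-2,5-dimethylphenyl in place of 4-acetylphenyl on an aromatic carbon. Within the data shown here, no step between two measured compounds corresponds to this exchange, so nothing measured shows how much it should move the result. Among the measured compounds shown here, the only information is that compound 3 registers no activity up to the limit, and that the other two values are weak as well. The step of an at least 1.3-fold lower number from compound 3 to compound 4 (0.12 log units; that floor lies within the scatter) is therefore expected to stay within the scatter of repeated measurements, with a real chance that compound 4 again reaches only the limit. Compound 4 is estimated at 15000 nM, in a range from 4000 nM to 40000 nM.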

Compound 4, half-maximal inhibitory concentration: > 20000 nM
Compound 4 gave a limit, no number; the forecaster's own chance of this, stated with the estimate: 55%; at least 1.3-fold (0.12 log units) between middle value and limit.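

In this assay, compound 3 and compound 4 each give only a limit of the assay, so no step can be read between them and the exchange of 4-acetylphenyl for 4-fluoro-2,5-dimethylphenyl stays without a size. Compound 4 joins the others at that limit: the limit of > 20000 nM in this assay, at which 3 of the 4 values shown sit.

The compounds shown leave open what the true potencies of compound 3 and compound 4 are.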